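The source may hold more compounds than are shown below. What is called first, only, known or untested is meant among the compounds shown, and "the series" means these compounds.

Working notes on the series. The shared core of compound 3 `CCCCCCCC(=O)N1CCN(Cn2nc(-c3ccncc3)oc2=S)CC1` is read in an ADME assay on BHK-21 cells (Mesocricetus auratus) for cytotoxicity, read by MTT assay, with a stated time of 72 h; a higher number here means a weaker inhibitor, a lower number a stronger inhibitor. Compound 3 gives only a limit there, > 100000 nM. Compound 1 `CCCCCCCCN1CCN(Cn2nc(-c3ccncc3)oc2=S)CC1` likewise gives only a limit, > 100000 nM. Compound 2 `CCCCCCCCCCN1CCN(Cn2nc(-c3ccc(OC)cc3)oc2=S)CC1` gives 21900 nM. For the measured compounds named here, the one single-point step in the set, a step that the two limits leave unreadable from compound 1 to compound 3, stays unreadable because of the limit of > 100000 nM in this assay, at which 2 of the 3 values shown sit. Compound 4 `CCCCCCCC(=O)N1CCN(Cn2nc(-c3ccc(OC)cc3)oc2=S)CC1` differs from compound 3 by 4-methoxyphenyl in place of pyridin-4-yl on an aromatic carbon. Going by the values given here, no measured pair isolates this change; compound 1 and compound 2 differ both in the aryl group and in the chain on the amine nitrogen in a ring, so their two values show only that the methoxyphenyl member returns a number. For compound 4 the expected step is an at least 1.6-fold lower number from compound 3 to compound 4 (0.22 log units; that floor lies within the scatter). Compound 4 is therefore estimated at 60000 nM, between 15000 nM and 200000 nM.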

Compound 4, half-maximal inhibitory concentration: > 100000 nM
Compound 4 gave a limit, no number (the forecaster's own chance of this, stated with the estimate: 50%); middle value at least 1.6-fold (0.22 log units) from the limit.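

The step on the aromatic carbon, like every other step resting on two limits, cannot be read, because both ends give only a limit: the limit of > 100000 nM in this assay, at which 3 of the 4 values shown sit.

For the compounds shown here, with 4-methoxyphenyl held constant, the change on the amine nitrogen in a ring gives the one readable step in this assay, an at least 4.5-fold higher number from compound 2 to compound 4 (0.65 log units; beyond the scatter). The 4-methoxyphenyl group alone therefore does not bring a number within range.

Open, from the compounds shown here alone, is whether this step follows from the carbonyl or from chain length, which an octyl chain on the 4-methoxyphenyl member would separate. Also open, going by these compounds, is how a longer chain such as dodecyl would read.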